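Swapping the Oxazole Substituent for Trifluoromethyl

A few compounds are considered here, and "the series" means these few. Any claim that something is new, unique, unknown or untested is made for them only; others in the source may bear on it.

Three compounds share one core and differ only in the small group attached to its five-membered ring. In an assay on isolated protein for inhibition of Fatty-acid amide hydrolase 1 (Rattus norvegicus) (a higher number here means a weaker inhibitor, a lower number a stronger inhibitor), compound 1 `Cc1coc(C(=O)CCCCCCc2ccccc2)n1` gives 520 nM, compound 2 `O=Cc1coc(C(=O)CCCCCCc2ccccc2)n1` gives 55 nM, and compound 3 `CN(C)C(=O)c1coc(C(=O)CCCCCCc2ccccc2)n1` gives 35 nM, the lowest of the three numbers, though its gap to compound 2 stays within the scatter (a 1.6-fold lower number from compound 2 to compound 3 (0.20 log units; within the scatter)).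

Compound 4 `O=C(CCCCCCc1ccccc1)c1nc(C(F)(F)F)co1` has not yet been measured. It differs from compound 3 by trifluoromethyl in place of dimethylcarbamoyl on an aromatic carbon.

Among the measured compounds shown here, the steps that bear on this change are a 15-fold lower number from compound 1 to compound 3 (1.17 log units; beyond the scatter) and a 9.5-fold lower number from compound 1 to compound 2 (0.98 log units; beyond the scatter): replacing a methyl by either carbonyl-bearing group lowered the number clearly. Trifluoromethyl is neither a methyl nor a carbonyl-bearing group, so no measured step covers it directly. Losing the dimethylcarbamoyl is expected to cost some potency, but less than the full return to the methyl compound, so a modest rise in this assay is expected: a 3.4-fold higher number from compound 3 to compound 4 (0.54 log units; beyond the scatter). For compound 4 the estimated value in this assay is 120 nM, with a range from 40 nM to 400 nM.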

Compound 4, inhibition constant: 3.7 nM
For compound 4 the middle estimate is 32-fold (1.51 log units) above the measured one, and the stated range ends above it.
By their numbers in this assay, from the lowest: compound 4; then compounds 3 and 2 (each within the scatter of the next); then compound 1.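

In this assay, this position does not need a carbonyl-bearing group for a low number: trifluoromethyl, with no carbonyl and no hydrogen-bond acceptor, gives a 9.5-fold lower number from compound 3 to compound 4 (0.98 log units; beyond the scatter) and a 15-fold lower number from compound 2 to compound 4 (1.17 log units; beyond the scatter). The earlier compounds shown here left open the reading that the carbonyl itself lowered the number, but compound 4 goes clearly past both carbonyl-bearing compounds, and the full span at this one position reaches a 140-fold lower number from compound 1 to compound 4 (2.15 log units; beyond the scatter). No measurement here explains why trifluoromethyl gives the lowest number of the series.

The compounds shown say nothing about how a nitrile, a carboxylic acid, an amine or a difluoromethyl at this position would compare with trifluoromethyl. They also leave open whether the same swap would give a similar step on a core with a shorter chain.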